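This account rests on a few compounds, and the source may have more. Where it says the series, first, only, none or still open, it means among the compounds named here.

Measured so far in an ADME assay on HEL cells (Homo sapiens) for cytotoxicity, with a stated time of 3 days; a higher number here means that more compound is tolerated, a lower number that less compound is tolerated:
compound 1, `Cc1cc(-c2ccsc2)c2ncc(CSCCc3ccccc3)n2c1` — > 50 ug/mL
compound 2, `Cc1cc(-c2cccc(C#N)c2)cn2c(CSCCc3ccccc3)cnc12` — > 50 ug/mL
compound 3, `Cc1cc(I)cn2c(CSCCc3ccccc3)cnc12` — > 50 ug/mL

In this assay compound 1 gives > 50 ug/mL, which is a limit of the assay and not a number. Compound 2 gives > 50 ug/mL in this assay, again a limit. Compound 3 also sits at a limit, > 50 ug/mL. Every value shown so far rests at the limit of > 50 ug/mL in this assay, at which 3 of the 3 values shown sit. For the measured compounds named here, the only measured step between two compounds that differ in one place is a step that the two limits leave unreadable from compound 2 to compound 3; its size is not readable, both of its ends being limits.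

Compound 4, `Cc1cc(I)c2ncc(CSCCc3ccccc3)n2c1`, has not yet been measured in this assay. It differs from compound 1 by iodo in place of thiophen-3-yl on an aromatic carbon. The step from compound 2 to compound 3, which also brings in iodo on an aromatic carbon, is the nearest comparison, but it gives no readable size. With all three values at the limit, no step beyond the scatter is expected in this assay, in either direction. Compound 4 is therefore expected to give about 50 ug/mL, in the range 30 ug/mL to 80 ug/mL, most likely reported again as a limit. The expected step is a number no higher from compound 1 to compound 4 (the limit leaves the size open).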

Compound 4, half-maximal cytotoxic concentration: > 50 ug/mL
Compound 4 ended at the assay's limit (the forecaster's own chance of this, stated with the estimate: 85%); the middle value sits exactly at the limit.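

The step between compound 1 and compound 4, iodo in place of thiophen-3-yl, cannot be read in this assay, as both values are limits: the limit of > 50 ug/mL in this assay, at which 4 of the 4 values shown sit.

The compounds shown leave open at what concentration any of them becomes cytotoxic, and whether the groups exchanged on the shared core change that concentration.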